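This account rests on a few compounds, and the source may have more. Where it says the series, first, only, none or still open, it means among the compounds named here.

For the measured compounds named here, in an ADME assay on HepG2 cells (Homo sapiens) for cytotoxicity, read by MTT assay, with a stated time of 72 h (on this read-out higher numbers stand for lower toxicity in this test and lower numbers for higher toxicity in this test), compound 2 `O=[N+]([O-])c1c(CS(=O)(=O)c2ccccc2)nc2c(C#CCO)cc(Cl)cn12` gives 10100 nM, the only actual number so far. Compound 1 `COc1cccc(C#Cc2cc(Cl)cn3c([N+](=O)[O-])c(CS(=O)(=O)c4ccccc4)nc23)c1` gives > 3900 nM in this assay, and this value is a limit. Compound 3 `CCC(O)CC#Cc1cc(Cl)cn2c([N+](=O)[O-])c(CS(=O)(=O)c3ccccc3)nc12` differs from compound 2 by 1-hydroxypropyl in place of hydroxy on a saturated chain carbon bound to a triple-bonded carbon. Going by the values given here, the only measured step is a step that the limit leaves unreadable from compound 1 to compound 2, and it gives no size to carry over. No step beyond the usual scatter is therefore expected in this assay, in either direction. The expected change is a 1.1-fold lower number from compound 2 to compound 3 (0.05 log units; within the scatter). For compound 3 the estimated value is 9000 nM, with an expected range from 3500 nM to 20000 nM.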

Compound 3, half-maximal cytotoxic concentration: > 62500 nM
Compound 3 ended at the assay's limit (the forecaster's own chance of this, stated with the estimate: 25%); middle value at least 6.9-fold (0.84 log units) from the limit.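

For the compounds shown here, replacing hydroxy with 1-hydroxypropyl on the saturated chain carbon bound to the triple-bonded carbon gives the first readable step at this position in this assay, towards lower toxicity in this test: an at least 6.1-fold higher number from compound 2 to compound 3 (0.79 log units; beyond the scatter). Compound 3 gives > 62500 nM, which is a limit. The step from compound 1 to compound 3 cannot be read, so only the change in chain length on the hydroxylated side chain has a direction. From the compounds shown here alone, it remains open whether the hydroxy group on the longer chain matters, and how an amine or a carboxylic acid at this place would read.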